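The compounds below may be only part of what the source reports. "The series", "measured", "known", "first", "only" and "open" are said of these compounds alone.

Measured so far in a functional assay on HepG2 cells (Homo sapiens) for antiproliferative activity, read by MTT assay, with a stated time of 48 h; a higher number here means a weaker inhibitor, a lower number a stronger inhibitor:
compound 1, `Brc1ccc(CSc2nnc(-c3cnccn3)o2)cc1`, 13200 nM
compound 2, `c1ccc(CSc2nnc(-c3cnccn3)o2)cc1`, 11200 nM
compound 3, `Brc1ccc(CSc2nnc(-c3cnccn3)s2)cc1`, 780 nM

Compound 3 stands lowest of the three numbers; its distances to compound 2 and to compound 1 both lie beyond the scatter, so among these three it is the strongest inhibitor. How the core of compound 3 differs from the core of compound 1 is not broken down here.

Compound 4, `c1ccc(CSc2nnc(-c3cnccn3)s2)cc1`, remains to be measured in this assay. It relates to compound 3 as compound 2 relates to compound 1. Compound 2 differs from compound 1 by hydrogen in place of bromo on an aromatic carbon and compound 4 differs from compound 3 by hydrogen in place of bromo on an aromatic carbon. The two place descriptions agree word for word, so this is the same change, occurring twice among the compounds shown.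

For the measured compounds named here, the one measured instance of the change, a 1.2-fold lower number from compound 1 to compound 2 (0.07 log units; within the scatter), lies within the scatter. On that single step rests the expectation for compound 4: a step of similar size, a 1.2-fold lower number from compound 3 to compound 4 (0.08 log units; within the scatter), is expected. Going by the values given here, compound 4 is therefore estimated at 650 nM, with a range from 300 nM to 1500 nM, the width reflecting that only one example of the change is measured and that it sits on a different core.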

Compound 4, half-maximal inhibitory concentration: 11400 nM
Beside the measured number, compound 4's estimate is 18-fold (1.24 log units) below it; measured number outside the range, above it.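

In this assay, hydrogen in place of bromo on an aromatic carbon gives a 15-fold higher number from compound 3 to compound 4 (1.16 log units; beyond the scatter), so on this core the bromo cannot be dropped without a large change in the number. For the compounds shown here, the step measured on the core of compound 1 therefore does not carry over to the core of compound 3, and the size of this change depends on the core it sits on: the same change on two cores in this assay, a 1.2-fold lower number (0.07 log units; within the scatter) from compound 1 to compound 2 and a 15-fold higher number (1.16 log units; beyond the scatter) from compound 3 to compound 4, 17-fold (1.24 log units) apart, beyond the scatter of two such steps This rests on only two matched pairs, and it shows neither why the two cores respond differently nor which response is more typical of the series.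

Still open, from the compounds shown here alone, is whether other groups on the same aromatic carbon, such as chloro, methyl, methoxy or an amine, would follow the core of compound 3 or the core of compound 1. Also open, going by these compounds, is whether the dependence on the core holds for substituents other than bromo, as a single substituent cannot settle that.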